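Swapping a Methyl for a Phenyl on the Shared Core

The source may hold more compounds than are shown below. What is called first, only, known or untested is meant among the compounds shown, and "the series" means these compounds.

Of the compounds shown here, three built on one shared core have been measured in a functional assay on HGC-27 cells (Homo sapiens) for inhibition, read by MTT assay, with a stated time of 72 h; on this read-out lower numbers stand for stronger inhibition and higher numbers for weaker inhibition. Compound 1 `Cc1cc(N2CC[C@@H](C)[C@@H](N(C)c3ncnc4[nH]ccc34)C2)n2ncnc2n1` gives 11300 nM in this assay. Compound 2 `CCCSc1nc2nc(C)cc(N3CC[C@@H](C)[C@@H](N(C)c4ncnc5[nH]ccc45)C3)n2n1` carries a propylsulfanyl group where compound 1 has hydrogen; in this assay compound 2 gives 20900 nM. Compound 3 `Cc1cc(N2CC[C@@H](C)[C@@H](N(C)c3ncnc4[nH]ccc34)C2)n2nc(SCC3CCCCC3)nc2n1`, carrying a (cyclohexylmethyl)sulfanyl group in place of that hydrogen, gives 11500 nM. Compound 1 has the lowest of the three numbers, yet its nearest neighbour is compound 3, with a 1.0-fold higher number from compound 1 to compound 3 (0.01 log units; within the scatter), and even the widest gap, a 1.8-fold higher number from compound 1 to compound 2 (0.27 log units; within the scatter), stays within the scatter, so the three cannot be told apart.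

Compound 4 `C[C@@H]1CCN(c2cc(-c3ccccc3)nc3ncnn23)C[C@@H]1N(C)c1ncnc2[nH]ccc12` has not yet been measured. It differs from compound 1 in one place: phenyl in place of methyl on an aromatic carbon. Within the data shown here, none of the measured steps touches this place; all three alter the sulfanyl substituent at another site, and each of them, including a 1.8-fold lower number from compound 2 to compound 3 (0.26 log units; within the scatter), stayed within the scatter. The shared core thus tolerated sizeable additions at one site without any change beyond the scatter, but the data give no direct guide for the present change. The step of a 1.0-fold lower number from compound 1 to compound 4 (0.01 log units; within the scatter) is therefore expected to be small, with no clear direction. Compound 4 is expected to give 11000 nM, within a plausible range from 4000 nM to 30000 nM.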

Compound 4, half-maximal inhibitory concentration: > 100000 nM
Compound 4: no number, only a limit; the forecaster's own chance of this, stated with the estimate: 10%; middle value at least 9.0-fold (0.95 log units) away from the limit.
By their numbers in this assay, from the lowest: compounds 1, 3 and 2 (each within the scatter of the next). At a limit, above all of these: compound 4.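

Propylsulfanyl and (cyclohexylmethyl)sulfanyl at the other site left the number within the scatter, but this aromatic carbon, next to the ring nitrogen, does not take every change so calmly: phenyl in place of methyl gives an at least 8.8-fold higher number from compound 1 to compound 4 (0.94 log units; beyond the scatter). Among these compounds, compound 4 is the only compound here that ends at a limit of the assay rather than at a number: the limit of > 100000 nM in this assay, at which 1 of the 4 values shown sits. So the shared core does not respond alike at its two sites, and a swap that brings in one six-membered aromatic ring of carbon only, with no hydrogen-bond donors or acceptors entering or leaving, is enough to carry compound 4 clear of the other three in this assay.

From the compounds shown here alone, with only methyl and phenyl at this position, it remains open whether a group as small as ethyl would already shift the number, and whether an amine or a pyridyl ring on this carbon would read like methyl or like phenyl. Going by these compounds, it is also open whether a sulfanyl group at the other site would alter anything in a compound that carries phenyl here.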